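A few compounds are considered here, and "the series" means these few. Any claim that something is new, unique, unknown or untested is made for them only; others in the source may bear on it.

Three compounds have been measured in a functional assay on HTB-54 cells (Homo sapiens) for cytotoxicity, read by MTT assay, with a stated time of 72 h; a higher number here means a weaker inhibitor of growth, a lower number a stronger inhibitor of growth:
compound 1, `N#C[Se]c1ccc(NC(=O)OCc2ccc([N+](=O)[O-])cc2)cc1`, gives 47600 nM;
compound 2, `N#C[Se]c1ccc(NC(=O)Oc2ccc(F)cc2)cc1`, gives 48400 nM;
compound 3, `CCCOC(=O)Nc1ccc([Se]C#N)cc1`, gives 51900 nM.

Compound 1 shows the lowest of the three numbers, yet compound 2 and compound 3 both lie within the usual scatter of it, so the three cannot be told apart on these figures. Compound 4, `N#C[Se]c1ccc(NC(=O)OCc2ccccc2)cc1`, has not yet been tested in this assay. It differs from compound 1 in one place: hydrogen in place of nitro on an aromatic carbon. For the measured compounds named here, no step between measured compounds of this kind is available. Since the three measured compounds, which differ from one another elsewhere in the molecule, all sit close together, the step is expected to be small, in no particular direction and within the scatter: a 1.1-fold higher number from compound 1 to compound 4 (0.02 log units; within the scatter). Compound 4 is therefore estimated at 50000 nM, with a range from 25000 nM to 100000 nM.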

Compound 4, concentration for total growth inhibition: 50800 nM
Compound 4: middle estimate off by 1.0-fold (0.01 log units), on the low side; low and high end bracket the measured number.
By their numbers in this assay, from the lowest: compounds 1, 2, 4 and 3 (each within the scatter of the next).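

Replacing the nitro with hydrogen on the aromatic carbon para to a large group gives a 1.1-fold higher number from compound 1 to compound 4 (0.03 log units; within the scatter) and so leaves the number within the scatter, which means the nitro is not needed at this position for the activity seen here. Phenyl in place of ethyl on the saturated chain carbon bound to an oxygen next to a carbonyl group gives a 1.0-fold lower number from compound 3 to compound 4 (0.01 log units; within the scatter) and so shows the same at this second place. Nothing available explains why either change has so little effect.

Going by these compounds, whether an amine or a carboxylic acid on that aromatic carbon would move the number beyond the scatter remains open, as does the effect of a longer chain at the second place.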